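Swapping a Pyridinyl Arm for a Dimethylaminophenyl Arm

The source may report more compounds than this note shows. Statements on the series, on what has been measured and on what is new or still open speak of the compounds shown alone.

Measured compounds:
compound 1 `COc1ccc(S(=O)(=O)N2CCc3cccc(-c4ccc([N+](=O)[O-])cc4)c32)cc1`: 34 nM
compound 2 `COc1ccc(S(=O)(=O)N2CCc3cccc(-c4cccnc4)c32)cc1`: 68.5 nM

In a functional assay on MKN-45 cells (Homo sapiens) for inhibition, with a stated time of 72 h (a higher number here means a weaker inhibitor, a lower number a stronger inhibitor), compound 1 gives 34 nM, while compound 2 gives 68.5 nM. Among the compounds with values here, compound 2 holds the highest of the two numbers, with compound 1 as its only neighbour; the step of a 2.0-fold higher number from compound 1 to compound 2 (0.30 log units; within the scatter) lies within the scatter, so no order between the two can be read.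

Compound 3 `COc1ccc(S(=O)(=O)N2CCc3cccc(-c4ccc(N(C)C)cc4)c32)cc1` differs from compound 2 in one place: 4-(dimethylamino)phenyl in place of pyridin-3-yl on an aromatic carbon.

Within the data shown here, the single measured step that bears on an exchange of this aromatic arm is a 2.0-fold higher number from compound 1 to compound 2 (0.30 log units; within the scatter), and it is within the scatter. Among the measured compounds shown here, compound 3 shares with compound 1 a six-membered aromatic ring of carbon only bearing one group, but no measured pair tests the dimethylamino group itself. The analysis therefore expects no step beyond the scatter, a 1.5-fold lower number from compound 2 to compound 3 (0.18 log units; within the scatter). Compound 3 is estimated at 45 nM, within 15 nM to 140 nM.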

Compound 3, half-maximal inhibitory concentration: 237 nM
The estimate for compound 3 lay 5.3-fold (0.72 log units) below the measured number; the measured number lies above the stated range.
By their numbers in this assay, from the lowest: compounds 1 and 2 (each within the scatter of the next); then compound 3.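

In this assay, this aromatic carbon had shown no readable difference between the first two arms, but it now responds to the group it carries: 4-(dimethylamino)phenyl in place of pyridin-3-yl gives a 3.5-fold higher number from compound 2 to compound 3 (0.54 log units; beyond the scatter). With a six-membered aromatic ring of carbon only kept in the arm, dimethylamino in place of nitro gives a 7.0-fold higher number from compound 1 to compound 3 (0.84 log units; beyond the scatter), so that ring alone does not set the number and the group on it counts. Nothing measured here accounts for either step.

Going by these compounds, it remains open whether this rise is particular to dimethylamino or would also appear with a primary amine, a methoxy group or a carboxylic acid on the same ring. On these data alone, since all three values come from one cell assay, it is also open whether the order would hold in any other test.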